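The source may report more compounds than this note shows. Statements on the series, on what has been measured and on what is new or still open speak of the compounds shown alone.

Measured in a functional assay on C8166 cells (Homo sapiens) for antiproliferative activity, read by MTT assay; a lower number here means that less compound is tolerated, a higher number that more compound is tolerated:
Compound 1 `Cc1cc(C)cc(S(=O)(=O)c2c(C(=O)NCC(N)=O)[nH]c3ccc(Cl)cc23)c1` gives > 100 uM 
Compound 2 `Cc1cc(C)cc(S(=O)(=O)c2c(C(=O)NN3CCOC3=O)[nH]c3ccc(Cl)cc23)c1` gives > 100 uM 
Compound 3 `Cc1cc(C)cc(S(=O)(=O)c2c(C(=O)NNC(C)C)[nH]c3ccc(Cl)cc23)c1` gives > 100 uM 

Each of these entries is a limit of the assay, not a number. Compound 3 therefore has only a limit, like the other two (the limit of > 100 uM in this assay, at which 3 of the 3 values shown sit).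

The next compound, compound 4 `CC(=O)NNC(=O)c1[nH]c2ccc(Cl)cc2c1S(=O)(=O)c1cc(C)cc(C)c1`, carries acetyl in place of isopropyl on an amine nitrogen. Going by the values given here, three measured steps bear on this change (a step that the two limits leave unreadable from compound 1 to compound 3 and a step that the two limits leave unreadable from compound 2 to compound 3 and a step that the two limits leave unreadable from compound 1 to compound 2), and none has a readable size. No direction can be drawn from them, so the expected step (a number no higher from compound 3 to compound 4 (the limit leaves the size open)) is none beyond the scatter in this assay on present data. Compound 4 is estimated at 100 uM with an expected range from 40 uM to 200 uM as its span.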

Compound 4, half-maximal toxic concentration: > 100 uM
Compound 4 was reported as a limit (the forecaster's own chance of this, stated with the estimate: 80%); the middle value lies on the limit itself.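

Compound 4 gives no readable step against compound 1, compound 2 or compound 3 in this assay because all four values are the same limit: the limit of > 100 uM in this assay, at which 4 of the 4 values shown sit.

On these data alone, whether any of these groups on the amide-type nitrogen changes the tolerated concentration remains open.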